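The compounds below may be only part of what the source reports. "The series", "measured", "known", "first", "only" and "open" are said of these compounds alone.

Measured so far in an assay on HEK293 cells for displacement of a labelled ligand from Melanocortin receptor 4 (Homo sapiens); a higher number here means a weaker inhibitor, a lower number a stronger inhibitor:
- compound 1 `Cc1ccc(CC(C)C(=O)N2CCN(c3ccc(C(F)(F)F)cc3[C@@H](N)CC(C)C)CC2)cc1C`: 240 nM
- compound 2 `COc1cc(CC(C)C(=O)N2CCN(c3ccc(C(F)(F)F)cc3[C@@H](N)CC(C)C)CC2)ccc1Cl`: 230 nM

Compound 2 and compound 1 share the same core and differ only in the aryl group on the chain; their two values in this assay lie within the usual scatter of each other, as the step of a 1.0-fold lower number from compound 1 to compound 2 (0.02 log units; within the scatter) shows, so neither can be called the stronger binder.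

Compound 3 `CC(C)C[C@H](N)c1cc(C(F)(F)F)ccc1N1CCN(C(=O)[C@H](C)Cc2ccc(Cl)cc2)CC1` has not yet been measured. It differs from compound 2 in one place:
1-(4-chlorobenzyl)ethyl in place of 1-(4-chloro-3-methoxybenzyl)ethyl on a carbonyl carbon

Going by the values given here, the only measured step that bears on this change is the one from compound 1 to compound 2, where a different aryl group on the same chain gave a 1.0-fold lower number from compound 1 to compound 2 (0.02 log units; within the scatter), a change within the scatter. Taking the methoxy group away is a smaller alteration of the same part of the molecule, so no step beyond the scatter is expected, though the defined stereocentre in compound 3 adds some uncertainty in either direction.

The estimate for compound 3 in this assay is therefore 200 nM, within a range of 80 nM to 500 nM, which amounts to an expected step of a 1.2-fold lower number from compound 2 to compound 3 (0.06 log units; within the scatter).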

Compound 3, inhibition constant: 31 nM
Estimate against measurement, compound 3: 6.5-fold (0.81 log units) above; measured number outside the range, below it.
By their numbers in this assay, from the lowest: compound 3; then compounds 2 and 1 (each within the scatter of the next).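

Until now, the aryl group on this chain seemed to make no difference in this assay: swapping one substitution pattern for another gave only a 1.0-fold lower number from compound 1 to compound 2 (0.02 log units; within the scatter). The new result shows that this part of the molecule can matter, with a 7.4-fold lower number from compound 2 to compound 3 (0.87 log units; beyond the scatter) and, against the dimethyl-substituted group, a 7.7-fold lower number from compound 1 to compound 3 (0.89 log units; beyond the scatter). The change is not a clean one, however, as the entering 1-(4-chlorobenzyl)ethyl group differs from the group in compound 2 both by lacking the methoxy group and by carrying a defined stereocentre, and nothing available here explains the stronger binding.

The compounds shown leave open how much of the step belongs to the loss of the methoxy group and how much to the defined stereocentre, a question that the opposite stereoisomer of compound 3, or a 4-chloro-3-methoxybenzyl analogue with the same defined stereocentre, would address. They also leave open what the chlorine contributes, which could be tested with a bromine, a fluorine or a nitrile in its place, or with an unsubstituted benzyl group.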